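The compounds below may be only part of what the source reports. "The series", "measured", "known", "first", "only" and "open" are said of these compounds alone.

In a functional assay on HCT-116 cells (Homo sapiens) for antiproliferative activity, read by MTT assay, with a stated time of 72 h (on this read-out lower numbers stand for stronger inhibition and higher numbers for weaker inhibition), compound 1 `O=C1O[C@H]([C@@H](O)Cn2cc(-c3ccc(Br)cc3)nn2)C(OCc2ccccc2)=C1OCc1ccccc1` gives 9420 nM, compound 2 `O=C1O[C@H]([C@@H](O)Cn2cc(CNS(=O)(=O)c3ccc(F)cc3)nn2)C(OCc2ccccc2)=C1OCc1ccccc1` gives 22900 nM, and compound 3 `CC(C)(C)c1cn(C[C@H](O)[C@H]2OC(=O)C(OCc3ccccc3)=C2OCc2ccccc2)nn1` gives 28300 nM. Compound 3 stands furthest from compound 1 (a 3.0-fold higher number from compound 1 to compound 3 (0.48 log units; beyond the scatter)); the other step that ends at it is within the scatter (a 1.2-fold higher number from compound 2 to compound 3 (0.09 log units; within the scatter)); the remaining step is a 2.4-fold higher number from compound 1 to compound 2 (0.39 log units; beyond the scatter). Compound 4 `O=C1O[C@H]([C@@H](O)Cn2cc(-c3cc(F)cc(F)c3)nn2)C(OCc2ccccc2)=C1OCc1ccccc1` differs from compound 3 in one place: 3,5-difluorophenyl in place of tert-butyl on an aromatic carbon. Among the measured compounds shown here, the step that bears on this change is the one from compound 1 to compound 3, where 4-bromophenyl gave way to tert-butyl (a 3.0-fold higher number from compound 1 to compound 3 (0.48 log units; beyond the scatter)); compound 4 brings back an aromatic ring of the same kind, so a move toward the number of compound 1 is expected. The expected step is a 2.4-fold lower number from compound 3 to compound 4 (0.37 log units; beyond the scatter). Compound 4 is estimated to give 12000 nM, within 5000 nM to 30000 nM.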

Compound 4, half-maximal inhibitory concentration: 48200 nM
Compound 4: middle estimate off by 4.0-fold (0.60 log units), on the low side; the whole stated range lies below it.
By their numbers in this assay, from the lowest: compound 1; then compounds 2, 3 and 4 (each within the scatter of the next, the first and the last beyond it).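

At this aromatic carbon, carrying an aromatic ring does not by itself give a number like that of compound 1: a 5.1-fold higher number from compound 1 to compound 4 (0.71 log units; beyond the scatter) separates two compounds that both carry one. Exchanging tert-butyl for 3,5-difluorophenyl gives a 1.7-fold higher number from compound 3 to compound 4 (0.23 log units; within the scatter), so the ring changes little against that group. Against the (((4-fluorophenyl)sulfonyl)amino)methyl group, the same ring gives a 2.1-fold higher number from compound 2 to compound 4 (0.32 log units; beyond the scatter). Plain phenyl and 4-chlorophenyl would help show whether the halogen's identity or its place on the ring matters here. Nothing available explains the gap between the two ring-bearing compounds.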